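Chloro to Nitro Exchange on Two Related Cores

The source may report more compounds than this note shows. Statements on the series, on what has been measured and on what is new or still open speak of the compounds shown alone.

Compound 1, `O=C1OC(c2ccc(Cl)cc2)=C/C1=C\c1ccc(Cl)cc1`: in a functional assay on the whole organism (strain Wistar) for inhibition, with Rattus norvegicus as the target, with stated times of 30 min and 2 h, at a dose of 20 mg/kg by the oral route (a higher number here means more inhibition at the dose given (going by the name of the read-out), a lower number less inhibition), compound 1 gives 40%.
Compound 2, `O=C1OC(c2ccc(Cl)cc2)=C/C1=C\c1ccc([N+](=O)[O-])cc1`: in this assay compound 2 gives 4%.
Compound 3, `O=C1/C(=C/c2ccc(Cl)cc2)C=C(c2ccc(Cl)cc2)N1Cc1ccccc1`: in this assay compound 3 gives 58.7%.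

Compound 1 and compound 2 differ in a single place, (nitro in place of chloro on an aromatic carbon). This exchange made a step of a number 36 percentage points lower from compound 1 to compound 2 (beyond the scatter). Compound 3 is built on a different core; the difference between the two cores is not broken down here. Compound 3 holds the highest of the three numbers, and its steps to compound 1 and compound 2 both lie beyond the scatter.

Compound 4, `O=C1/C(=C/c2ccc([N+](=O)[O-])cc2)C=C(c2ccc(Cl)cc2)N1Cc1ccccc1`, has not yet been measured. It stands to compound 3 as compound 2 stands to compound 1, through the same change, (nitro in place of chloro on an aromatic carbon), which occurs twice among these compounds. Since the same change already appears once on a measured pair, the step is expected to be a number 35.7 percentage points lower from compound 3 to compound 4 (beyond the scatter), an expectation that rests on a number 36 percentage points lower from compound 1 to compound 2 (beyond the scatter). The cores differ, so the transfer is uncertain. Compound 4 is therefore estimated at 23% in this assay, within a range from 5% to 45%.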

Compound 4, a percentage reported as inhibition, in the whole organism at one dose (the size of the read-out at that dose, not a potency): 12%
The estimate for compound 4 lay 11 percentage points above the measured number; the measured number falls inside the stated range.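

In this assay the exchange of 4-chlorophenyl to 4-nitrophenyl on the second core gave a step of a number 46.7 percentage points lower from compound 3 to compound 4 (beyond the scatter), and this step agrees with the one seen on the first core: the same change on two cores in this assay, a number 36 percentage points lower (beyond the scatter) from compound 1 to compound 2 and a number 46.7 percentage points lower (beyond the scatter) from compound 3 to compound 4, 10.7 percentage points apart, within the scatter of two such steps. Across these two pairs, then, the change carried from the core of compound 1 to the core of compound 3 in the same direction, with no difference in size that can be told apart from the scatter. This does not show that the change would carry to any further core, since it rests on two pairs and on a read-out taken at a single dose, which gives no potency and no reason for the drop.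

The compounds shown leave open how an amine or a carboxylic acid would read in the place held here by chloro or nitro. They also leave open whether the same step would appear if the benzyl group on the ring nitrogen of compound 3 gave way to a longer chain.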